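The source may report more compounds than this note shows. Statements on the series, on what has been measured and on what is new or still open speak of the compounds shown alone.

Series notes, a functional assay on HepG2 cells (Homo sapiens) for antiproliferative activity, read by MTT assay, with a stated time of 48 h; a lower number here means a stronger inhibitor, a higher number a weaker inhibitor. Compound 3 `Cc1ccccc1-n1nncc1CN1C(=O)C2(C(C#N)=C(N)Oc3c(N)cc4nc5ccccc5nc4c32)c2ccccc21` reaches only the limit of the assay, > 50000 nM, not a number. Compound 1 `N#CC1=C(N)Oc2c(c3nc4ccccc4nc3c3ccccc23)C12C(=O)N(Cc1cnnn1-c1cccc(Cl)c1)c1ccccc12` likewise sits at a limit, > 50000 nM. Within the data shown here, compound 2 `N#CC1=C(N)Oc2c(c3nc4ccccc4nc3c3ccccc23)C12C(=O)N(Cc1cnnn1-c1ccc(S(N)(=O)=O)cc1)c1ccccc12` gives 42200 nM in this assay; the only measured step, an at least 1.1-fold lower number from compound 1 to compound 2 (0.07 log units; that floor lies within the scatter), is a change of the aryl group on the aromatic nitrogen and stays within the scatter, and the limit of > 50000 nM in this assay, at which 2 of the 3 values shown sit, marks where most of the series sits. Compound 4 `Cc1ccc(-n2nncc2CN2C(=O)C3(C(C#N)=C(N)Oc4c(N)cc5nc6ccccc6nc5c43)c3ccccc32)cc1C` differs from compound 3 by 3,4-dimethylphenyl in place of 2-methylphenyl on an aromatic nitrogen. This is again a change of the aryl group on the aromatic nitrogen, so for compound 4 no step beyond the scatter is expected: a step that the limit leaves unreadable from compound 3 to compound 4. Compound 4 is estimated at 60000 nM in this assay, between 30000 nM and 150000 nM, most likely again reported only as a limit.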

Compound 4, half-maximal inhibitory concentration: > 50000 nM
Compound 4 was reported as a limit; the forecaster's own chance of this, stated with the estimate: 80%; the middle value is on the limit's open side.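

Compound 3 and compound 4 both stand only as limits in this assay, so no step can be read between them, and the series stays at that limit: the limit of > 50000 nM in this assay, at which 3 of the 4 values shown sit.

From the compounds shown here alone, whether 3,4-dimethylphenyl and 2-methylphenyl on the aromatic nitrogen differ at all in this read-out remains open.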